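The source may report more compounds than this note shows. Statements on the series, on what has been measured and on what is new or still open speak of the compounds shown alone.

Three compounds have so far been measured in an ADME assay on GES1 cells (Homo sapiens) for inhibition, read by MTT assay, with a stated time of 72 h; on this read-out lower numbers stand for stronger inhibition and higher numbers for weaker inhibition:

Compound 1 `Cc1cc(Nc2cc(-c3ccccc3)[nH]n2)n2ncnc2n1` — > 50000 nM; this is a limit of the assay, not a number.
Compound 2 `Cc1cc(Nc2cc(-c3ccccc3)[nH]n2)n2nc(SCc3csc4ccccc34)nc2n1` — 29200 nM.
Compound 3 `Cc1cc(Nc2cc(-c3ccccc3)[nH]n2)n2nc(SCc3nc4ccccc4[nH]3)nc2n1` — 27800 nM.

Compound 3 gives the lowest of the two numbers, but its nearest neighbour, compound 2, sits within the scatter of it, so the two cannot be told apart. Compound 4 `Cc1cc(Nc2cc(-c3ccccc3)[nH]n2)n2nc(SCCc3ccccc3)nc2n1` is the next compound to be measured. It differs from compound 3 in one place: benzyl in place of 1H-benzimidazol-2-yl on a saturated chain carbon bound to a sulfur.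

Among the compounds with values here, one measured step bears on a change at this very spot, the swap of the aromatic group on the saturated chain carbon bound to a sulfur, and it is a 1.1-fold lower number from compound 2 to compound 3 (0.02 log units; within the scatter). The two steps that add the whole sulfanyl arm, an at least 1.7-fold lower number from compound 1 to compound 2 (0.23 log units; that floor lies within the scatter) and an at least 1.7-fold lower number from compound 1 to compound 3 (0.25 log units; that floor lies within the scatter), show only that the arm itself lowers the number by a modest floor. From this, no step beyond the scatter is expected when benzyl takes the place of 1H-benzimidazol-2-yl.

Compound 4 is therefore estimated at 28000 nM, with a range from 12000 nM to 60000 nM. That estimate means a 1.0-fold higher number from compound 3 to compound 4 (0.00 log units; within the scatter), a step expected to stay within the scatter.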

Compound 4, half-maximal inhibitory concentration: 37400 nM
The estimate for compound 4 lay 1.3-fold (0.13 log units) below the measured number; the range from low to high includes it.
By their numbers in this assay, from the lowest: compounds 3, 2 and 4 (each within the scatter of the next). At a limit, above all of these: compound 1.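

In this assay, benzyl in place of 1H-benzimidazol-2-yl gives a 1.3-fold higher number from compound 3 to compound 4 (0.13 log units; within the scatter), and benzyl in place of 1-benzothiophen-3-yl gives a 1.3-fold higher number from compound 2 to compound 4 (0.11 log units; within the scatter). So, among these compounds, giving up a fused ring, and with 1H-benzimidazol-2-yl also its counted hydrogen-bond donor and acceptor, produces no step beyond the scatter at this position. Phenethylsulfanyl in place of hydrogen on an aromatic carbon gives an at least 1.3-fold lower number from compound 1 to compound 4 (0.12 log units; that floor lies within the scatter), which is only a floor because one end of the step is a limit and not a number: the limit of > 50000 nM in this assay, at which 1 of the 4 values shown sits.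

From the compounds shown here alone, it remains open whether this arm truly lowers the number by more than the scatter. Going by these compounds, it also remains open whether an amine or a carboxylic acid on the ring of the arm, or a longer chain on the sulfur, would produce a step beyond the scatter.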